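Swapping an amino-bearing ring for a fluorinated one

The source may hold more compounds than are shown below. What is called first, only, known or untested is meant among the compounds shown, and "the series" means these compounds.

Of the compounds shown here, three sharing one core have been tested in a functional assay on UO-31 cells (Homo sapiens) for cytotoxicity, read by sulforhodamine B assay, with a stated time of 48 h, tested at 1 uM; on this read-out higher numbers stand for a weaker effect at the one concentration tested and lower numbers for a stronger effect. Compound 1, `COc1cc(-c2cc(/C=C/C(=O)c3ccc(N)cc3)[nH]n2)cc(OC)c1OC`, gives 71%, the lowest of the three numbers. Compound 2, `COc1cc(-c2cc(/C=C/C(=O)c3ccc(Cl)c(Cl)c3)[nH]n2)cc(OC)c1OC`, gives 81%, and compound 3, `COc1ccc(C(=O)/C=C/c2cc(-c3cc(OC)c(OC)c(OC)c3)n[nH]2)cc1`, gives 77%. The step of a number 10 percentage points higher from compound 1 to compound 2 (within the scatter) and the step of a number 6 percentage points higher from compound 1 to compound 3 (within the scatter) both stay inside the usual scatter, so no difference between the three can be claimed.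

Compound 4, `COc1cc(-c2cc(/C=C/C(=O)c3ccc(F)c(F)c3)[nH]n2)cc(OC)c1OC`, differs from compound 1 in one place: 3,4-difluorophenyl in place of 4-aminophenyl on a carbonyl carbon. The closest guide is the step from compound 1 to compound 2, where a ring bearing two halogens likewise replaced the 4-aminophenyl on the carbonyl carbon, and that step was a number 10 percentage points higher from compound 1 to compound 2 (within the scatter), within the scatter. On that basis the step of a number 7 percentage points higher from compound 1 to compound 4 (within the scatter) is expected to be small as well, likely a little upward but not beyond the scatter. Compound 4 is therefore estimated at 78% in this assay, with a range from 66% to 90%.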

Compound 4, a percentage reported as activity, at one concentration (the size of the read-out at that concentration, not a potency): 84%
The estimate for compound 4 lay 6 percentage points below the measured number, and the stated range covers the measured number.
By their numbers in this assay, from the lowest: compounds 1, 3, 2 and 4 (each within the scatter of the next, the first and the last beyond it).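

Within the data shown here, on the carbonyl carbon, 3,4-difluorophenyl in place of 4-aminophenyl gives the first step beyond the scatter in this assay in this set, a number 13 percentage points higher from compound 1 to compound 4 (beyond the scatter) and so a modestly weaker effect at the one concentration tested. The steps of a number 7 percentage points higher from compound 3 to compound 4 (within the scatter) and a number 3 percentage points higher from compound 2 to compound 4 (within the scatter) both stay inside the scatter, so compound 4 cannot be told apart from the compounds carrying 4-methoxyphenyl or 3,4-dichlorophenyl. Nothing measured here bears on why the step from the amino-bearing ring arises.

As far as these compounds go, it remains open whether the step follows the loss of the amine or the arrival of fluorine, and a plain phenyl, a 4-fluorophenyl or a 4-(dimethylamino)phenyl ring on the same carbonyl carbon could help separate the two. Potency also remains open, as one concentration cannot give it.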